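From Methyl to Cyclopentyl: Estimating Compound 4

The source may hold more compounds than are shown below. What is called first, only, known or untested is meant among the compounds shown, and "the series" means these compounds.

compound 1 `COc1ccc(Nc2cc(C)oc(=O)c2)cc1` — > 30 uM
compound 2 `COc1ccc(Nc2cc(-c3ccc4ccccc4c3)oc(=O)c2)cc1` — 0.13 uM
compound 3 `COc1ccccc1Nc1cc(-c2ccccc2)oc(=O)c1` — 0.49 uM

Of the compounds shown here, three have been measured in a functional assay on KBVIN cells (Homo sapiens) for cytotoxicity, read by MTT assay, with a stated time of 72 h; a higher number here means that more compound is needed for the effect, a lower number that less compound is needed. Compound 1 gives only a limit of this assay, > 30 uM, which is the limit of > 30 uM in this assay, at which 1 of the 3 values shown sits. Compound 2 gives 0.13 uM in this assay. Compound 3 gives 0.49 uM in this assay. Where compound 1 stands is therefore known only as a limit, with no number.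

Compound 4 (`COc1ccc(Nc2cc(C3CCCC3)oc(=O)c2)cc1`) differs from compound 1 by cyclopentyl in place of methyl on an aromatic carbon. No step between two measured compounds is shown, so the size of this change rests on expectation alone. The estimated step of an at least 6.0-fold lower number from compound 1 to compound 4 (0.77 log units; beyond the scatter) is expected to be a decrease beyond the scatter, though smaller than the gap compound 2 and compound 3 open against compound 1. Compound 4 is estimated at 5 uM, within 0.5 uM to 30 uM.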

Compound 4, concentration for half-maximal effect: 4.98 uM
For compound 4 the middle estimate is 1.0-fold (0.00 log units) above the measured one; low and high end bracket the measured number.
By their numbers in this assay, from the lowest: compound 2; then compound 3; then compound 4. At a limit, above all of these: compound 1.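

In this assay, cyclopentyl in place of methyl on an aromatic carbon next to the ring oxygen gives an at least 6.0-fold lower number from compound 1 to compound 4 (0.77 log units; beyond the scatter), the first step read at this position. It shows that this position responds to the group it carries, and that a five-membered non-aromatic ring of carbon only is enough to give a number. The full size of the step remains unknown, since compound 1 stands at a limit: the limit of > 30 uM in this assay, at which 1 of the 4 values shown sits.

From the compounds shown here alone, whether the ring itself matters or only the added carbon atoms stays open, as a pentyl chain here would tell. So does the effect of an amine or a carboxylic acid at this position.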